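From bromo to dimethylamino on the shared core

The source may report more compounds than this note shows. Statements on the series, on what has been measured and on what is new or still open speak of the compounds shown alone.

Measured so far:
Compound 1 `O=C1/C(=C/c2ccc(Cl)cc2)CCCc2ccccc21`: 33000 nM
Compound 2 `O=C1/C(=C/c2ccc(Br)cc2)CCCc2ccccc21`: 54700 nM

In a functional assay on MOLT-4 cells (Homo sapiens) for inhibition (on this read-out lower numbers stand for stronger inhibition and higher numbers for weaker inhibition), compound 2 gives 54700 nM, which lies within the scatter of compound 1. Compound 3 `CN(C)c1ccc(/C=C2\CCCc3ccccc3C2=O)cc1` carries dimethylamino in place of bromo on an aromatic carbon, para to a large group: dimethylamino in place of bromo on an aromatic carbon. Among the compounds with values here, the only measured step, a 1.7-fold higher number from compound 1 to compound 2 (0.22 log units; within the scatter), exchanges chloro for bromo and stays within the scatter. It does not test a dimethylamino group, so it is weak guidance, and no step beyond the scatter is expected in this assay. The estimate amounts to an expected 1.6-fold lower number from compound 2 to compound 3 (0.19 log units; within the scatter). For compound 3 the estimated value is 35000 nM, with an expected range of 10000 nM to 100000 nM.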

Compound 3, half-maximal inhibitory concentration: 5250 nM
For compound 3 the middle estimate is 6.7-fold (0.82 log units) above the measured one; the measured number lies below the stated range.
By their numbers in this assay, from the lowest: compound 3; then compounds 1 and 2 (each within the scatter of the next).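

In this assay, this position proves sensitive to the group it carries: the exchange of chloro for bromo stayed within the scatter, whereas dimethylamino gives a 10-fold lower number from compound 2 to compound 3 (1.02 log units; beyond the scatter) and a 6.3-fold lower number from compound 1 to compound 3 (0.80 log units; beyond the scatter) on the same core. Replacing a halogen with dimethylamino therefore moves the number in a way that exchanging one halogen for the other did not. Nothing available here explains this stronger inhibition. The compounds shown leave open whether the nitrogen alone is enough or its two methyl groups also matter. A plain amine or a methoxy group at this position would help separate those possibilities.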